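Compound 3 to compound 4: shortening the side chain

A few compounds are considered here, and "the series" means these few. Any claim that something is new, unique, unknown or untested is made for them only; others in the source may bear on it.

Measured in a functional assay on SW1573 cells (Homo sapiens) for antiproliferative activity, read by sulforhodamine B assay, with a stated time of 48 h; on this read-out lower numbers stand for stronger inhibition of growth and higher numbers for weaker inhibition of growth:
- compound 1 `COC(=O)C#CC(CCc1ccccc1)O/C=C/C(=O)OC` gives 2600 nM
- compound 2 `CCC(C)C(C#CC(=O)OC)O/C=C/C(=O)OC` gives 910 nM
- compound 3 `COC(=O)C#CC(O/C=C/C(=O)OC)C(C)C` gives 750 nM

Compound 3 lies within the scatter of compound 2, and its number is lower than that of compound 1 by more than the scatter. Compound 4 `COC(=O)C#CC(C)O/C=C/C(=O)OC` differs from compound 3 by methyl in place of isopropyl on a saturated chain carbon bound to an oxygen on an unsaturated carbon and a triple-bonded carbon. Going by the values given here, the only measured single-place step, a 1.2-fold lower number from compound 2 to compound 3 (0.08 log units; within the scatter), also removes a methyl and stays within the scatter. Among the compounds with values here, no measured compound carries methyl at this place, so the evidence is thin. No step beyond the scatter is therefore expected in this assay. The estimated step is a 1.2-fold higher number from compound 3 to compound 4 (0.08 log units; within the scatter). Compound 4 is estimated at 900 nM, with an expected range of 350 nM to 2400 nM.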

Compound 4, concentration for 50% growth inhibition: 1700 nM
Compound 4: middle estimate off by 1.9-fold (0.28 log units), on the low side, and the stated range covers the measured number.
By their numbers in this assay, from the lowest: compounds 3, 2, 4 and 1 (each within the scatter of the next, the first and the last beyond it).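

In this assay, going by these compounds alone, methyl in place of isopropyl at this place gives the first single-place step beyond the scatter (a 2.3-fold higher number from compound 3 to compound 4 (0.36 log units; beyond the scatter)), so the position is not indifferent to the group it carries. The other two steps stay within the scatter, with methyl in place of sec-butyl (a 1.9-fold higher number from compound 2 to compound 4 (0.27 log units; within the scatter)) and with hydrogen in place of benzyl (a 1.5-fold lower number from compound 1 to compound 4 (0.18 log units; within the scatter)), so only isopropyl is set apart from methyl here. Nothing at hand explains this step.

From the compounds shown here alone, whether an unbranched longer chain, an amine or a carboxylic acid at this place would fit this picture remains open.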